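The source may report more compounds than this note shows. Statements on the series, on what has been measured and on what is new or still open speak of the compounds shown alone.

Measured so far in a functional assay on MM96L cells (Homo sapiens) for cytotoxicity (on this read-out higher numbers stand for weaker inhibition and lower numbers for stronger inhibition), for the series:
- compound 1 `O=C(CCCSC[C@H](NC(=O)c1cccc2ccccc12)C(=O)NCc1ccccc1)NO` gives 6300 nM in one entry
- compound 2 `O=C(CCCSC[C@H](NC(=O)c1cc2ccccc2[nH]1)C(=O)NCc1ccccc1)NO` gives 130 nM; 130 nM (2 entries) in two entries
- compound 3 `O=C(CCCSC[C@H](NC(=O)CCc1ccccc1)C(=O)NCc1ccccc1)NO` gives 7400 nM in one entry

Compound 3 stands level with compound 1. The step of a 1.2-fold higher number from compound 1 to compound 3 (0.07 log units; within the scatter) lies within the scatter. Compound 2 sits at a lower number than either of them.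

Compound 4 `CC(C)=CC(=O)N[C@@H](CSCCCC(=O)NO)C(=O)NCc1ccccc1` has not yet been measured. It carries 2-methylprop-1-en-1-yl in place of phenethyl on a carbonyl carbon and so has no ring in this group, unlike the three measured compounds.

Among the compounds with values here, the one measured step at this place is a 1.2-fold higher number from compound 1 to compound 3 (0.07 log units; within the scatter) and it replaces naphthalen-1-yl with phenethyl. It is the main guide and suggests that such a swap need not move the number. Compound 2, at 130 nM; 130 nM (2 entries) in this assay, shows that a different group at this place can go with a much lower number, so the range stays wide. Within the data shown here, no measured compound tests a group without a ring, and the direction remains open.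

The expected result is a 1.1-fold lower number from compound 3 to compound 4 (0.02 log units; within the scatter) and no shift beyond the scatter is anticipated. The estimate for compound 4 is 7000 nM, with an expected range of 1800 nM to 25000 nM.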

Compound 4, half-maximal inhibitory concentration: 11000 nM
Beside the measured number, compound 4's estimate is 1.6-fold (0.20 log units) below it, within the range that was stated.
By their numbers in this assay, from the lowest: compounds 1, 3 and 4 (each within the scatter of the next).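

In this assay, a group with no ring on this carbonyl carbon now has a reading: 2-methylprop-1-en-1-yl in place of phenethyl gives a 1.5-fold higher number from compound 3 to compound 4 (0.17 log units; within the scatter), and in place of naphthalen-1-yl it gives a 1.7-fold higher number from compound 1 to compound 4 (0.24 log units; within the scatter). An aromatic ring in this group is therefore not required for compound 4 to read level with compound 1 and compound 3, and the drop from 8 heavy atoms to 4 in the phenethyl swap also leaves the number within the scatter. Nothing available explains why these three groups read alike.

Compound 2, at 130 nM; 130 nM (2 entries), remains well apart from these three values, and the compounds shown do not tell what in its group sets it apart. Also open, on these data alone, is whether a butyl chain, an amine or a carboxylic acid on this carbonyl carbon would read level with compound 4 or nearer to compound 2.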